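The source may report more compounds than this note shows. Statements on the series, on what has been measured and on what is new or still open speak of the compounds shown alone.

Compound 1 `COc1ccc(/C=C/C(=O)NCc2ccc(OCc3nc(C)c(C)nc3C)c(OC)c2)cc1`: 5050 nM
Compound 2 `COc1cc(/C=C/C(=O)NCc2ccc(OCc3nc(C)c(C)nc3C)c(OC)c2)cc(OC)c1`: 8660 nM

In a functional assay on SH-SY5Y cells (Homo sapiens) for cytotoxicity, read by MTT assay, with stated times of 24 h and 4 h (a lower number here means that less compound is needed, a higher number that more compound is needed for the effect), compound 2 gives 8660 nM, the highest of the two numbers shown; its only neighbour is compound 1 with 5050 nM, and the step of a 1.7-fold higher number from compound 1 to compound 2 (0.23 log units; within the scatter) lies within the scatter. Compound 3 `COc1cc(CNC(=O)/C=C/c2cc(OC)c(OC)c(OC)c2)ccc1OCc1nc(C)c(C)nc1C` differs from compound 2 by methoxy in place of hydrogen on an aromatic carbon, which, cut one bond further out, reads 3,5-dimethoxyphenyl to 3,4,5-trimethoxyphenyl. For the measured compounds named here, the one step that bears on this, a 1.7-fold higher number from compound 1 to compound 2 (0.23 log units; within the scatter), also moved methoxy groups on the same ring and stayed within the scatter, so no change beyond the scatter is expected in this assay. Compound 3 is therefore estimated at 8000 nM, between 3500 nM and 18000 nM. The expected step is a 1.1-fold lower number from compound 2 to compound 3 (0.03 log units; within the scatter).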

Compound 3, half-maximal effective concentration: 11500 nM
For compound 3 the middle estimate is 1.4-fold (0.16 log units) below the measured one; the measured number falls inside the stated range.
By their numbers in this assay, from the lowest: compounds 1, 2 and 3 (each within the scatter of the next, the first and the last beyond it).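

In this assay, methoxy in place of hydrogen on the aromatic carbon ortho to two methoxy groups gives a 1.3-fold higher number from compound 2 to compound 3 (0.12 log units; within the scatter) and so does not separate compound 3 from compound 2. Only the whole change from 4-methoxyphenyl to 3,4,5-trimethoxyphenyl leaves the scatter, with a 2.3-fold higher number from compound 1 to compound 3 (0.36 log units; beyond the scatter) as a modest step. Nothing at hand explains either step.

The compounds shown leave open how this position would read with a group other than methoxy, such as a hydroxyl or an amine. They also leave open whether a longer chain on the oxygen would change the number.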